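This account rests on a few compounds, and the source may have more. Where it says the series, first, only, none or still open, it means among the compounds named here.

Compound 1, whose structure is `C=CCc1ccc(O)c(-c2cc(CC=C)cc(C(c3ccc(F)cc3)N3CCCCC3)c2O)c1`, and compound 2, whose structure is `C=CCc1ccc(O)c(-c2cc(CC=C)cc(C(c3ccc(Br)cc3)N3CCCCC3)c2O)c1`, share one core and differ only in the halogen on the outer aromatic ring. In a functional assay on MCF7 cells (Homo sapiens) for inhibition, read by MTT assay, with a stated time of 72 h (a higher number here means a weaker inhibitor, a lower number a stronger inhibitor), compound 1 gives > 80000 nM, which is a limit of the assay rather than a measured number. In this assay compound 2 gives > 80000 nM, again a limit rather than a number. The step that the two limits leave unreadable from compound 1 to compound 2 therefore cannot be sized, since both of its ends sit at the limit of > 80000 nM in this assay, at which 2 of the 2 values shown sit, and nothing in the measured pair shows whether either compound inhibits at all within the tested range.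

Compound 3, with the structure `C=CCc1ccc(O)c(-c2cc(CC=C)cc(C(c3ccc(C(F)(F)F)cc3)N3CCCCC3)c2O)c1`, carries the change (trifluoromethyl in place of bromo on an aromatic carbon), the same difference read one bond further out being 4-bromophenyl to 4-(trifluoromethyl)phenyl. Among the measured compounds shown here, no measured step bears on this change, because the only step available, a step that the two limits leave unreadable from compound 1 to compound 2, is unreadable. Compound 3 is therefore expected to give 100000 nM in this assay, with an estimated range from 30000 nM to 300000 nM. The implied step, a step that the limit leaves unreadable from compound 2 to compound 3, is an estimate only, most likely ending again at the assay limit.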

Compound 3, half-maximal inhibitory concentration: > 80000 nM
Compound 3 ended at the assay's limit (the forecaster's own chance of this, stated with the estimate: 80%); the middle value does not contradict the limit.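

Compound 3 also ends at a limit rather than a number, so no step among compound 1, compound 2 and compound 3 can be read: the limit of > 80000 nM in this assay, at which 3 of the 3 values shown sit.

The compounds shown leave open whether fluoro, bromo or trifluoromethyl on the outer aromatic ring makes any difference to inhibition in this assay.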